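Ortho-chloro in place of meta-chloro on a purine amine

The source may report more compounds than this note shows. Statements on the series, on what has been measured and on what is new or still open speak of the compounds shown alone.

Three compounds share one core and differ in the cycloalkylamine and in the aryl group. Compound 1 `CCn1c(-c2ccccc2)nc2c(NC3CCC3)ncnc21` gives 6 nM in an assay on CHO cells for displacement of a labelled ligand from adenosine receptor A1 (Homo sapiens), read by scintillation counting, with a stated time of 3 h; a lower number here means a stronger inhibitor, a higher number a weaker inhibitor. Compound 2 `Cn1c(-c2cccc(Cl)c2)nc2c(NC3CCCC3)ncnc21` gives 6.5 nM in this assay, and compound 3 `Cn1c(-c2ccccc2)nc2c(NC3CCCCC3)ncnc21` gives 5.7 nM in this assay. The three numbers lie within the scatter of one another, so compound 2 stands with the others rather than apart from them; its nearest neighbour is compound 1 and its furthest is compound 3, both within the scatter.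

Compound 4 `Cn1c(-c2ccccc2Cl)nc2c(NC3CCCC3)ncnc21` differs from compound 2 in one place (2-chlorophenyl in place of 3-chlorophenyl on an aromatic carbon). Going by the values given here, no measured pair here shows the effect of moving the chlorine on the aryl ring, so the expectation rests on the narrow spread of compound 1, compound 2 and compound 3. For compound 4 a modest weakening is expected, with the step of a 2.3-fold higher number from compound 2 to compound 4 (0.36 log units; beyond the scatter) judged most likely to fall at or somewhat beyond the scatter. Compound 4 is therefore estimated at 15 nM, within 5 nM to 50 nM.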

Compound 4, inhibition constant: 37 nM
For compound 4 the middle estimate is 2.5-fold (0.39 log units) below the measured one; the measured number falls inside the stated range.
By their numbers in this assay, from the lowest: compounds 3, 1 and 2 (each within the scatter of the next); then compound 4.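

Moving the chlorine gives a 5.7-fold higher number from compound 2 to compound 4 (0.76 log units; beyond the scatter) in this assay, the first step in this set that lies beyond the scatter. Compound 1, compound 2 and compound 3 stayed within the scatter of one another, whereas this pair shows that, on this aromatic carbon between two ring nitrogen atoms, 2-chlorophenyl and 3-chlorophenyl are not interchangeable even though they have the same atoms. Nothing available here accounts for the size of this step.

The compounds shown leave open how an unsubstituted phenyl group, a fluorophenyl group or a methoxyphenyl group on the same carbon, with the rest of compound 2 unchanged, would compare with these two chlorophenyl groups. They also leave open whether the step would persist with an ethyl group in place of the methyl group.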